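Methylcarbamoyl in Place of Hydrogen on Compound 3

The source may report more compounds than this note shows. Statements on the series, on what has been measured and on what is new or still open speak of the compounds shown alone.

Compound 3 `c1ccc2c(c1)CCC2c1ncc[nH]1` gives 54% in a functional assay on CHO cells for agonist activity at Alpha-1A adrenergic receptor (Homo sapiens), read by FLIPR and calcium flux; on this read-out higher numbers stand for larger maximal responses and lower numbers for smaller maximal responses. Among the three measured compounds it stands second highest: compound 2 `Cc1oncc1-c1cccc2c1CCC2c1ncc[nH]1` gives 63%, and the step of a number 9 percentage points lower from compound 2 to compound 3 (within the scatter) lies within the scatter, while compound 1 `Cn1cc(-c2cccc3c2CCC3c2ncc[nH]2)cn1` gives 12%, and the step of a number 42 percentage points higher from compound 1 to compound 3 (beyond the scatter) lies well beyond it. Compound 4 `CNC(=O)c1cccc2c1CCC2c1ncc[nH]1` differs from compound 3 by methylcarbamoyl in place of hydrogen on an aromatic carbon. Going by the values given here, no measured step places a methylcarbamoyl on this aromatic carbon; the nearest guides are a number 42 percentage points higher from compound 1 to compound 3 (beyond the scatter) and a number 9 percentage points lower from compound 2 to compound 3 (within the scatter), which show that a group on this aromatic carbon can leave the response unchanged or change it strongly. Compound 4 is therefore expected at 40% (range 10% to 70%), an expected step of a number 14 percentage points lower from compound 3 to compound 4 (beyond the scatter) whose size is uncertain.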

Compound 4, largest response reached (Emax), in percent of the reference or control that the assay uses: 59%
For compound 4 the middle estimate is 19 percentage points below the measured one; measured number inside the range.
By their numbers in this assay, from the lowest: compound 1; then compounds 3, 4 and 2 (each within the scatter of the next).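

In this assay a methylcarbamoyl on this aromatic carbon gives a response that cannot be told from that with hydrogen, the step being a number 5 percentage points higher from compound 3 to compound 4 (within the scatter) on the shared core. The same holds against the 5-methyl-1,2-oxazol-4-yl group, with a number 4 percentage points lower from compound 2 to compound 4 (within the scatter) as the step, whereas a number 47 percentage points higher from compound 1 to compound 4 (beyond the scatter) sets the 1-methyl-1H-pyrazol-4-yl group apart as the only one of the four substituents with a clearly smaller response. Nothing available explains why that group alone stands apart. From the compounds shown here alone, whether an amine, a carboxylic acid or a longer chain on this carbon would keep the response or lose it remains open.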